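A few compounds are considered here, and "the series" means these few. Any claim that something is new, unique, unknown or untested is made for them only; others in the source may bear on it.

Measured in a physicochemical assay for solubility, in phosphate buffer, measured as kinetic solubility; on this read-out higher numbers stand for higher solubility and lower numbers for lower solubility:
- Compound 1 `CC(C)[C@@H](c1ccc(-c2ccc3cccc(F)c3c2)[nH]c1=O)[C@H]1OC(=O)NC1=O`: 31600 nM
- Compound 2 `CC(C)[C@H](C[C@H]1SC(=O)NC1=O)c1ccc(-c2ccc3cccc(F)c3c2)[nH]c1=O`: 31200 nM

Compound 2, at 31200 nM, stands level with compound 1, at 31600 nM, the two values lying within the scatter of each other. The next compound to be read is compound 3 `CC(C)[C@H](C[C@@H]1OC(=O)NC1=O)c1ccc(-c2ccc3cccc(F)c3c2)[nH]c1=O`, which differs from compound 2 in one place: 2,4-dioxo-1,3-oxazolidin-5-yl in place of 2,4-dioxo-1,3-thiazolidin-5-yl on a saturated chain carbon, two bonds along the chain from an aromatic carbon. For the measured compounds named here, only one measured step bears on this change, and it is a 1.0-fold lower number from compound 1 to compound 2 (0.01 log units; within the scatter). Going by the values given here, that step put (2,4-dioxo-1,3-thiazolidin-5-yl)methyl in place of 2,4-dioxo-1,3-oxazolidin-5-yl, so it joins the exchange of these two rings with a change on the chain, and no measured step shows the exchange alone. With this single step as a guide, no shift beyond the scatter is expected in this assay, and no direction can be favoured. The estimated step is a 1.0-fold lower number from compound 2 to compound 3 (0.02 log units; within the scatter). For compound 3 the expected value is 30000 nM, within an estimated range of 14000 nM to 60000 nM.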

Compound 3, solubility: 21100 nM
The estimate for compound 3 lay 1.4-fold (0.15 log units) above the measured number, and the stated range covers the measured number.
By their numbers in this assay, from the lowest: compounds 3, 2 and 1 (each within the scatter of the next).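

In this assay, the exchange of 2,4-dioxo-1,3-thiazolidin-5-yl for 2,4-dioxo-1,3-oxazolidin-5-yl on a saturated chain carbon, two bonds along the chain from an aromatic carbon, can now be read by itself, and it gives a 1.5-fold lower number from compound 2 to compound 3 (0.17 log units; within the scatter). The change on the chain can also be read with the ring type held the same: (2,4-dioxo-1,3-oxazolidin-5-yl)methyl in place of 2,4-dioxo-1,3-oxazolidin-5-yl gives a 1.5-fold lower number from compound 1 to compound 3 (0.18 log units; within the scatter). Neither the ring exchange nor the added methylene link therefore carries this read-out beyond the scatter in these compounds, and no accompanying measurement offers an explanation for the values.

The compounds shown leave open whether a carboxylic acid or an amine in place of these rings would produce a step beyond the scatter. They also leave open how a longer chain between the ring and the saturated chain carbon would read, and whether 2,4-dioxo-1,3-thiazolidin-5-yl placed directly on that carbon would stand level with compound 1 and its ring.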